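The compounds below may be only part of what the source reports. "The series", "measured", "known", "first", "only" and "open" are said of these compounds alone.

Three compounds of this series carry the same core and differ only in the group attached through an oxygen on a saturated carbon. Compound 1 `CC(C)=CC[C@@H](OC(=O)CC(C)(O)c1ccccc1)C1=CC(=O)c2c(O)ccc(O)c2C1=O` gives 85700 nM in a functional assay on HeLa cells (Homo sapiens) for cytotoxicity, read by MTT assay; on this read-out lower numbers stand for stronger inhibition and higher numbers for weaker inhibition. Compound 2 `CCCC(O)CC(=O)O[C@H](CC=C(C)C)C1=CC(=O)c2c(O)ccc(O)c2C1=O` gives 59300 nM in this assay. For compound 3 `CC(C)=CC[C@@H](OC(=O)C1CCCCO1)C1=CC(=O)c2c(O)ccc(O)c2C1=O` this assay reports only a limit, > 100000 nM. So compound 3 stands at the weak end of what has been measured, and its number is only bounded from one side (the limit of > 100000 nM in this assay, at which 1 of the 3 values shown sits).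

The measured steps are all small: a 1.4-fold lower number from compound 1 to compound 2 (0.16 log units; within the scatter), an at least 1.1-fold higher number from compound 1 to compound 3 (0.06 log units; that floor lies within the scatter) and an at least 1.6-fold higher number from compound 2 to compound 3 (0.22 log units; that floor lies within the scatter). Each of them changes only the acyl part of the ester, and none of them moves the read-out beyond the scatter.

Compound 4 `CC(C)=CC[C@@H](OCC(C)O)C1=CC(=O)c2c(O)ccc(O)c2C1=O` is not yet measured. Its difference from compound 3 is 2-hydroxypropyl in place of (oxan-2-yl)carbonyl on an oxygen on a saturated carbon. This is a different kind of change from those measured, since the carbonyl is lost and an ether with a hydrogen-bond donor takes its place. Among the measured compounds shown here, no measured step bears directly on it, so the only guide is that the three measured compounds sit close together at weak inhibition. The estimate for compound 4 is therefore 100000 nM, within a range from 40000 nM to 300000 nM, meaning an expected step of a number no higher from compound 3 to compound 4 (the limit leaves the size open).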

Compound 4, half-maximal inhibitory concentration: 24700 nM
Beside the measured number, compound 4's estimate is 4.0-fold (0.61 log units) above it; the measured number lies below the stated range.
By their numbers in this assay, from the lowest: compound 4; then compounds 2 and 1 (each within the scatter of the next). At a limit, above all of these: compound 3.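

Up to this point, every measured change stayed within the acyl part of the ester, and none moved the number beyond the scatter in this assay. Among the compounds shown here, replacing the ester with an ether that carries 2-hydroxypropyl on the same oxygen is the first change to do so, giving an at least 4.0-fold lower number from compound 3 to compound 4 (0.60 log units; beyond the scatter) and a 2.4-fold lower number from compound 2 to compound 4 (0.38 log units; beyond the scatter). Thus the carbonyl on this oxygen is not required for the cytotoxic effect read here, and the compound without it gives a lower number than the two esters it is directly compared with, although the first of these steps is only a floor because compound 3 carries a limit and not a number: the limit of > 100000 nM in this assay, at which 1 of the 4 values shown sits.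

Losing the carbonyl and changing to a smaller group without a ring happen together in these steps, so the compounds shown cannot say which of the two matters, or whether the hydroxyl of 2-hydroxypropyl plays any part. A plain propyl ether would test the hydroxyl directly, and an amine in its place would show whether another group is accepted at this position.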